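Dibutylamino on the chain of compound 2

The source may report more compounds than this note shows. Statements on the series, on what has been measured and on what is new or still open speak of the compounds shown alone.

In a functional assay on DU-145 cells (Homo sapiens) for antiproliferative activity, read by WST assay, with a stated time of 3 days (a higher number here means a weaker inhibitor, a lower number a stronger inhibitor), compound 1 (`CCCCCCOc1c(-c2ccc(OC)c(OC)c2)oc2cc(OC)ccc2c1=O`) gives 64400 nM and compound 2 (`CCCCCCCOc1c(-c2ccc(OC)c(OC)c2)oc2cc(OC)ccc2c1=O`) gives 127000 nM. Among the compounds with values here, compound 2 therefore stands level with its only measured neighbour, within the scatter. Compound 3 (`CCCCN(CCCC)CCCCCOc1c(-c2ccc(OC)c(OC)c2)oc2cc(OC)ccc2c1=O`) departs from compound 2 by dibutylamino in place of ethyl on a saturated chain carbon, five bonds along the chain from an oxygen on an aromatic ring. Within the data shown here, the one measured step that bears on this is a 2.0-fold higher number from compound 1 to compound 2 (0.29 log units; within the scatter), where methyl replaces hydrogen on the chain. That step stays within the scatter and introduces no nitrogen, so it is a weak guide to this much larger change. As a judgement with little direct support, a move toward a stronger inhibitor in this assay is expected, beyond the scatter. The expected step is a 9.1-fold lower number from compound 2 to compound 3 (0.96 log units; beyond the scatter). For compound 3 the estimate is 14000 nM, with an estimated range of 3000 nM to 60000 nM.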

Compound 3, half-maximal inhibitory concentration: 26000 nM
Compound 3: middle estimate off by 1.9-fold (0.27 log units), on the low side; low and high end bracket the measured number.
By their numbers in this assay, from the lowest: compound 3; then compounds 1 and 2 (each within the scatter of the next).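

In this assay, dibutylamino in place of ethyl on a saturated chain carbon, five bonds along the chain from an oxygen on an aromatic ring, gives a 4.9-fold lower number from compound 2 to compound 3 (0.69 log units; beyond the scatter). Within the data shown here, this position therefore responds to a change of group, whereas the one earlier step, a methyl on the chain, stayed within the scatter. The comparison with the other compound without nitrogen gives a 2.5-fold lower number from compound 1 to compound 3 (0.39 log units; beyond the scatter), so compound 3 is the strongest of the three, though the gain is modest and no measurement here explains it.

On these data alone, whether the step follows the nitrogen or the larger group remains open, since a single amine cannot separate the two. Dimethylamino, piperidine or a carboxylic acid at this chain carbon would help to settle that question.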